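A few compounds are considered here, and "the series" means these few. Any claim that something is new, unique, unknown or untested is made for them only; others in the source may bear on it.

Measured compounds:
compound 1, `CCCC[C@](C)(OC)[C@@H](O)/C=C/C1[C@H](O)CC(=O)[C@@H]1C/C=C\CCCC(=O)OC`: in a functional assay on the whole organism (Cricetulus griseus) with Cricetinae gen. sp. as the target (a lower number here means that less compound is needed, a higher number that more compound is needed for the effect), compound 1 gives > 1 mg/kg, a limit of the assay rather than a number.
compound 2, `CCCC[C@@](C)(OC)[C@@H](O)/C=C/C1[C@H](O)CC(=O)[C@@H]1CCCCCCC(=O)OC`: in this assay compound 2 gives > 2.5 mg/kg, likewise a limit and not a number.

Compound 1 therefore stands only on (the limit of > 1 mg/kg in this assay, at which 1 of the 2 values shown sits). Compound 2 stands only on (the limit of > 2.5 mg/kg in this assay, at which 1 of the 2 values shown sits). Going by the values given here, because both values are limits, no step between measured compounds can be drawn from them, and no size of effect for either compound is actually known.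

Compound 3, `CCCC[C@](C)(OC)[C@H](O)/C=C/C1[C@H](O)CC(=O)[C@@H]1C/C=C\CCCC(=O)OC`, has not yet been measured. Its relation to compound 1 is the two compounds have the same atoms and bonds; at least one stereo element is drawn with a configuration in one of them and without one in the other: 1 of 7 stereo elements differ; a stereocentre at a saturated chain carbon is drawn S in compound 1 and R in compound 3. With compound 1 known only at a limit, the account expects no step beyond the scatter from compound 1 to compound 3, a step that the limit leaves unreadable from compound 1 to compound 3, since nothing measured points in either direction.

For compound 3 the expected value in this assay is estimated at 2 mg/kg, with a range from 0.5 mg/kg to 10 mg/kg, and it is expected that the assay will again most likely return only a limit.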

Compound 3, dose for half-maximal effect: > 1 mg/kg
Compound 3: no number, only a limit; the forecaster's own chance of this, stated with the estimate: 70%; the middle value lies beyond the limit too.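

In this assay compound 3 gives > 1 mg/kg, a limit of the assay and not a number. Going by these compounds alone, compound 1 likewise stands only on a limit, and no step from compound 1 to compound 3 can be read. The compounds shown leave open whether the configuration of the stereocentre at a saturated chain carbon changes the dose in this assay at all.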